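Swapping a Carboxy Group for an Amide-Bearing Chain

The compounds below may be only part of what the source reports. "The series", "measured", "known", "first", "only" and "open" are said of these compounds alone.

Three compounds share one core and differ only in what sits on an amine nitrogen in a ring. Compound 1 `Cc1cccc2c1nc(COc1ccc(Cl)cc1)n2CCCC1CCNCC1` carries a hydrogen there, and in an assay on AV12 cells for binding affinity to Neuropeptide Y receptor type 1 (Homo sapiens) (on this read-out lower numbers stand for stronger inhibition and higher numbers for weaker inhibition), compound 1 gives 335 nM. Compound 2 `Cc1cccc2c1nc(COc1ccc(Cl)cc1)n2CCCC1CCN(Cc2ccccc2)CC1` carries a benzyl group, and compound 2 gives 109 nM. Compound 3 `Cc1cccc2c1nc(COc1ccc(Cl)cc1)n2CCCC1CCN(CC(=O)O)CC1` carries a carboxymethyl group, and compound 3 gives 2190 nM, the highest number of the three. The step of a 6.5-fold higher number from compound 1 to compound 3 (0.82 log units; beyond the scatter) and the step of a 20-fold higher number from compound 2 to compound 3 (1.30 log units; beyond the scatter) both show the carboxy-bearing chain going with the higher number, whereas a 3.1-fold lower number from compound 1 to compound 2 (0.49 log units; beyond the scatter) shows a benzyl group lowering it.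

Compound 4 `Cc1cccc2c1nc(COc1ccc(Cl)cc1)n2CCCC1CCN(CCCC(N)=O)CC1` has not been measured. It differs from compound 3 in one place: 2-carbamoylethyl in place of carboxy on a saturated chain carbon bound to an amine nitrogen in a ring. The carboxy group that accompanied the weakest binding is removed, and a longer chain ending in an amide takes its place. Within the data shown here, no measured step involves such an amide, so the expectation rests only on the two steps that made the carboxy group look costly. The expected step to compound 4 is a 7.8-fold lower number from compound 3 to compound 4 (0.89 log units; beyond the scatter), toward a lower number. The estimate for compound 4 is 280 nM, within a range from 80 nM to 900 nM.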

Compound 4, inhibition constant: 88 nM
Compound 4: the middle estimate sits 3.2-fold (0.50 log units) above what was measured; low and high end bracket the measured number.
By their numbers in this assay, from the lowest: compounds 4 and 2 (each within the scatter of the next); then compound 1; then compound 3.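

The step of a 25-fold lower number from compound 3 to compound 4 (1.40 log units; beyond the scatter) shows that this assay responds strongly to the group on this amine nitrogen in a ring, although the carboxy group and the 2-carbamoylethyl group that replaces it each count one hydrogen-bond donor and one acceptor. The step of a 3.8-fold lower number from compound 1 to compound 4 (0.58 log units; beyond the scatter) shows that a group with no ring can also lower the number relative to hydrogen, which only the benzyl group of compound 2 had done before, while the carboxymethyl group of compound 3 remains the one case shown that goes the other way. The step of a 1.2-fold lower number from compound 2 to compound 4 (0.09 log units; within the scatter) lies within the scatter, so 3-carbamoylpropyl and benzyl cannot be told apart here, and a ring in this group is not needed to reach numbers of this size.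

The change to compound 4 alters chain length and chain end together, so only a carboxylic acid on the longer chain or an amide on the shorter chain could separate the two. Nothing shown here explains why the numbers move as they do at this position.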